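The compounds below may be only part of what the source reports. "The series", "measured", "known", "first", "only" and "open" are said of these compounds alone.

Measured so far in a functional assay on HeLa cells (Homo sapiens) for cytotoxicity, read by MTT assay, with a stated time of 72 h; on this read-out higher numbers stand for weaker inhibition and lower numbers for stronger inhibition:
compound 1 `O=C(c1ccccc1)N(/N=N/c1ccc([N+](=O)[O-])cc1Br)c1ccc([N+](=O)[O-])cc1Br`, 1530 nM
compound 2 `O=C(c1ccc(F)cc1)N(/N=N/c1ccc([N+](=O)[O-])cc1Br)c1ccc([N+](=O)[O-])cc1Br`, 580 nM

For the measured compounds named here, compound 2 has the lowest number of the two, with compound 1 nearest; the only measured step, a 2.6-fold lower number from compound 1 to compound 2 (0.42 log units; beyond the scatter), separates them. Compound 3 `CC(=O)OCC(=O)N(/N=N/c1ccc([N+](=O)[O-])cc1Br)c1ccc([N+](=O)[O-])cc1Br` differs from compound 2 by acetoxymethyl in place of 4-fluorophenyl on a carbonyl carbon. That single measured step altered a substituent on the aromatic ring that here leaves entirely, so it does not bear on this exchange, and neither direction nor size of the change in this assay is constrained by the data. Compound 3 is expected at 1500 nM, range 350 nM to 7000 nM. The estimated step is a 2.6-fold higher number from compound 2 to compound 3 (0.41 log units; beyond the scatter), held with wide uncertainty.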

Compound 3, half-maximal inhibitory concentration: 490 nM
Compound 3: middle estimate off by 3.1-fold (0.49 log units), on the high side; the range from low to high includes it.
By their numbers in this assay, from the lowest: compounds 3 and 2 (each within the scatter of the next); then compound 1.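

In this assay, the 4-fluorophenyl on the carbonyl carbon can be exchanged for acetoxymethyl, which has no ring, with a 1.2-fold lower number from compound 2 to compound 3 (0.07 log units; within the scatter) as the result. This position therefore accepts a group other than an aromatic ring, and the same exchange made against the phenyl of compound 1 gives a 3.1-fold lower number from compound 1 to compound 3 (0.49 log units; beyond the scatter) as its step. No supporting data bear on why this position tolerates the exchange.

Open, on these data alone, is whether the ester within acetoxymethyl matters, or whether a plain propyl chain or an aminomethyl group on the same carbonyl carbon would give similar numbers.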